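The source may hold more compounds than are shown below. What is called first, only, known or untested is meant among the compounds shown, and "the series" means these compounds.

Measured so far in a functional assay on MV4-11 cells (Homo sapiens) for antiproliferative activity, with a stated time of 6 days, tested at 6.25 uM; on this read-out lower numbers stand for a weaker effect and higher numbers for a stronger effect at the one concentration tested:

compound 1, `CNC(=O)N1CCCc2ccc(NC(=O)c3ccc(-c4ccn(C)n4)cc3)cc21`: 97%
compound 2, `CNC(=O)N1CCCc2ccc(NC(=O)c3cccc(-c4ccn(S(C)(=O)=O)n4)c3)cc21`: 37%
compound 3, `CNC(=O)N1CCCc2ccc(NC(=O)c3cccc(-c4cnn(S(C)(=O)=O)c4)c3)cc21`: 18%

Compound 1 stands highest of the three numbers; compound 2 lies lower and compound 3 a further step below that, both gaps beyond the scatter. Compound 2 and compound 3 differ from compound 1 in more than one place, so their distance from it cannot be assigned to any single change.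

The next compound, compound 4, `CNC(=O)N1CCCc2ccc(NC(=O)c3ccc(-c4cn[nH]c4)cc3)cc21`, has not yet been measured in this assay. Its change from compound 1 is 1H-pyrazol-4-yl in place of 1-methyl-1H-pyrazol-3-yl on an aromatic carbon, on an aromatic carbon of a six-membered ring of carbon only, para to a large group.

Among the compounds with values here, one measured step bears on it: the shift of attachment on the pyrazole, a number 19 percentage points lower from compound 2 to compound 3 (beyond the scatter). That step was modest and downward, though it ran on the 1-(methylsulfonyl) pair rather than between 1-methyl and the free ring nitrogen, so it is only a partial guide; nothing measured here isolates the loss of the methyl group. On that basis a downward step of similar modest size is expected, a number 17 percentage points lower from compound 1 to compound 4 (beyond the scatter), with compound 1 already near the top of the scale limiting how much room there is above. Compound 4 is therefore estimated at 80%, within 55% to 97%.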

Compound 4, a percentage reported as inhibition, at one concentration (the size of the read-out at that concentration, not a potency): 98.3%
The estimate for compound 4 lay 18.3 percentage points below the measured number; the measured number lies above the stated range.
By their numbers in this assay, from the lowest: compound 3; then compound 2; then compounds 1 and 4 (each within the scatter of the next).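

In this assay the exchange of 1-methyl-1H-pyrazol-3-yl for 1H-pyrazol-4-yl, on an aromatic carbon of a six-membered aromatic ring of carbon only and para to a large group, gives a number 1.3 percentage points higher from compound 1 to compound 4 (within the scatter) at the one concentration tested, so this position accepts the change with no loss of effect on this read-out. The change moves the attachment on the pyrazole, removes the methyl group and adds a hydrogen-bond donor, yet the downward shift seen as a number 19 percentage points lower from compound 2 to compound 3 (beyond the scatter) on the 1-(methylsulfonyl) pair does not carry over to this pair. No measured information is available to explain this tolerance.

With compound 1 and compound 4 both close to the top of the scale at a single concentration, any difference in potency between them stays unresolved, and the separate contributions of attachment and methyl loss cannot be told apart. As far as these compounds go, it also remains open whether this position would accept a pyrazole carrying a longer chain or an amine, a 1-(methylsulfonyl)pyrazole, or a carboxylic acid in place of the ring.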